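The source may hold more compounds than are shown below. What is called first, only, known or untested is meant among the compounds shown, and "the series" means these compounds.

Compound 1 `O=C(Nc1cc(-c2ccccc2)nn1-c1ccccc1)c1ccccc1` gives 4180 nM in an assay on HEK293 cells for displacement of a labelled ligand from metabotropic glutamate receptor 5 (Rattus norvegicus) (a lower number here means a stronger inhibitor, a higher number a weaker inhibitor), the highest of the three numbers measured. Compound 2 `O=C(Nc1cc(-c2ccccc2)nn1-c1ccccc1)c1cccc(C(F)(F)F)c1` gives 1650 nM in this assay, and compound 3 `O=C(Nc1cc(-c2ccccc2)nn1-c1ccccc1)c1ccc(Cl)c(Cl)c1` gives 160 nM in this assay. The steps are a 2.5-fold lower number from compound 1 to compound 2 (0.40 log units; beyond the scatter), a 26-fold lower number from compound 1 to compound 3 (1.42 log units; beyond the scatter) and a 10-fold lower number from compound 2 to compound 3 (1.01 log units; beyond the scatter); all three change the group on the carbonyl carbon. Compound 4 `O=C(Nc1cc(-c2ccccc2)nn1-c1ccccc1F)c1ccccc1` differs from compound 1 by fluoro in place of hydrogen on an aromatic carbon, ortho to a large group, and leaves the group on the carbonyl carbon untouched. Within the data shown here, no measured step bears on a change at this place, so the known steps give no direction for it. Compound 4 is therefore expected to stay near compound 1 in this assay, with a step of a 1.3-fold lower number from compound 1 to compound 4 (0.12 log units; within the scatter), not beyond the scatter. The estimate for compound 4 is 3200 nM, within 1100 nM to 10000 nM.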

Compound 4, inhibition constant: 2700 nM
For compound 4 the middle estimate is 1.2-fold (0.07 log units) above the measured one; the range from low to high includes it.
By their numbers in this assay, from the lowest: compound 3; then compounds 2, 4 and 1 (each within the scatter of the next, the first and the last beyond it).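

Fluoro in place of hydrogen on an aromatic carbon, ortho to a large group, is the first change away from the group on the carbonyl carbon, and in this assay it gives a 1.5-fold lower number from compound 1 to compound 4 (0.19 log units; within the scatter). This place therefore tolerates phenyl to 2-fluorophenyl without a shift beyond the scatter. No measurement on hand explains this result.

Going by these compounds, whether a larger group at this place, such as methoxy or a dimethylamino group, would also leave the number unmoved remains open. Also open, on these data alone, is whether 2-fluorophenyl would hold its result alongside the 3,4-dichlorophenyl group on the carbonyl carbon.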